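The source may report more compounds than this note shows. Statements on the series, on what has been measured and on what is new or still open speak of the compounds shown alone.

Working notes on the series. For the measured compounds named here, compound 1 (`COc1ccc(CN(C(=O)CSc2nc3ccccc3s2)c2cc(OC)c(OC)c(OC)c2)cc1N=[N+]=[N-]`) gives 14400 nM in a functional assay on PC-3 cells (Homo sapiens) for antiproliferative activity, read by MTT assay, with a stated time of 48 h (a higher number here means a weaker inhibitor, a lower number a stronger inhibitor), and holds the higher of the two numbers so far. Compound 2 (`COc1ccc2nc(SCC(=O)N(Cc3ccc(OC)c(O)c3)c3cc(OC)c(OC)c(OC)c3)sc2c1`) gives 4110 nM there, a lower number by more than the scatter. Compound 3 (`COc1ccc(CN(C(=O)CSc2nc3ccccc3s2)c2cc(OC)c(OC)c(OC)c2)cc1F`) carries a single change from compound 1: fluoro in place of azido on an aromatic carbon on an aromatic carbon, ortho to a methoxy group and meta to a large group. Put another way, 3-azido-4-methoxybenzyl becomes 3-fluoro-4-methoxybenzyl. Going by the values given here, no measured pair shows this swap or any other single change, so the expectation is loose. In this assay a moderate step to a lower number is expected, although a result within the scatter of compound 1 remains possible. The estimated step is a 1.8-fold lower number from compound 1 to compound 3 (0.26 log units; within the scatter) and remains tentative. The expected value for compound 3 is 8000 nM (range 3000 nM to 20000 nM).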

Compound 3, half-maximal inhibitory concentration: 20100 nM
Compound 3: the middle estimate sits 2.5-fold (0.40 log units) below what was measured; measured number outside the range, above it.
By their numbers in this assay, from the lowest: compound 2; then compounds 1 and 3 (each within the scatter of the next).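

In this assay, for the compounds shown here, replacing azido with fluoro on this aromatic carbon gives a 1.4-fold higher number from compound 1 to compound 3 (0.14 log units; within the scatter), the first single-change pair. At this position, ortho to a methoxy group, azido (3 heavy atoms, 1 hydrogen-bond acceptor) and fluoro (1 heavy atom, 0 hydrogen-bond acceptors) therefore cannot be told apart in this assay on the core of compound 1, despite the difference in those counts. No measurement is at hand that bears on this result.

Going by these compounds, whether an amine or a carboxylic acid on this same carbon would move the number beyond the scatter remains open. The reading also rests on one pair in one assay, so whether the swap behaves the same way on another core is unsettled.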